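An Open-Chain Group Replaces the Furan in Compound 3

This account rests on a few compounds, and the source may have more. Where it says the series, first, only, none or still open, it means among the compounds named here.

Compound 3 `Cc1ccc(-c2ccccc2NCC2=NCCN2)o1` gives 2.69 nM in a functional assay for activation of Alpha-1A adrenergic receptor (Homo sapiens), read by calcium flux (on this read-out higher numbers stand for an effect only at larger amounts of compound and lower numbers for an effect already at smaller amounts), the lowest of the three numbers. Compound 1 `c1ccc(-c2cnco2)c(NCC2=NCCN2)c1` gives 17.4 nM and compound 2 `Cc1nc(-c2ccccc2NCC2=NCCN2)no1` gives 724 nM; the steps of a 6.5-fold lower number from compound 1 to compound 3 (0.81 log units; beyond the scatter) and a 270-fold lower number from compound 2 to compound 3 (2.43 log units; beyond the scatter) both lie beyond the scatter. Compound 4 `CC/C(=N/OC)c1ccccc1NCC1=NCCN1` carries a group of 6 heavy atoms (4 carbon, 1 nitrogen, 1 oxygen; no ring) in place of a group of 6 heavy atoms (5 carbon, 1 oxygen; one five-membered aromatic ring with 1 hetero atom), on an aromatic carbon. Among the measured compounds shown here, no measured step exchanges the five-membered aromatic ring for a group without a ring; the two measured steps only show that exchanging one five-membered ring for another moved the number by a modest to large amount, with compound 3 holding the lowest value. A step upward in this assay is therefore expected, of the size an 11-fold higher number from compound 3 to compound 4 (1.05 log units; beyond the scatter). Compound 4 is estimated at 30 nM, within a range from 5 nM to 200 nM.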

Compound 4, half-maximal effective concentration: 87.1 nM
For compound 4 the middle estimate is 2.9-fold (0.46 log units) below the measured one, within the range that was stated.
By their numbers in this assay, from the lowest: compound 3; then compound 1; then compound 4; then compound 2.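

In this assay, a ring at this aromatic carbon proves not to be required for an effect: the open-chain group gives a 32-fold higher number from compound 3 to compound 4 (1.51 log units; beyond the scatter). It does not fall to the end of the series, with an 8.3-fold lower number from compound 2 to compound 4 (0.92 log units; beyond the scatter), although it remains behind the oxazole, with a 5.0-fold higher number from compound 1 to compound 4 (0.70 log units; beyond the scatter). No measurement offered here accounts for this order. Open, as far as these compounds go, is whether a longer chain or an amine at this place could bring the number back towards that of compound 3, and whether the opposite geometry at the double bond would shift it.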